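Phenyl for 3,5-dichloro-4-hydroxyphenyl on two cores

This account rests on a few compounds, and the source may have more. Where it says the series, first, only, none or still open, it means among the compounds named here.

Measured so far:
- compound 1 `CO[C@@H]1C/C=C(\C)C(=O)N(C)[C@@H](C(C)C)C(=O)N[C@H](Cc2ccccc2)C(=O)N[C@@H](C(C)C)C(=O)O[C@H](c2ccccc2)[C@H](C)/C=C/C=C/1C`: > 100 nM (a limit)
- compound 2 `CO[C@@H]1C/C=C(\C)C(=O)N(C)[C@@H](C(C)C)C(=O)N[C@H](Cc2cc(Cl)c(O)c(Cl)c2)C(=O)N[C@@H](C(C)C)C(=O)O[C@H](c2ccccc2)[C@H](C)/C=C/C=C/1C`: 42.1 nM
- compound 3 `CC[C@H](C)[C@H]1C(=O)N[C@H](Cc2cc(Cl)c(O)c(Cl)c2)C(=O)N[C@@H](C(C)(C)O)C(=O)O[C@H](c2ccccc2)[C@H](C)/C=C/C=C(\C)[C@H](OC)C[C@@H]2O[C@@]2(C)C(=O)N1C`: 17 nM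

In a functional assay on HCT-116 cells (Homo sapiens) for antiproliferative activity, read by MTT assay, with a stated time of 72 h (on this read-out higher numbers stand for weaker inhibition and lower numbers for stronger inhibition), compound 2 gives 42.1 nM. Compound 1 gives only a limit of the assay in this assay, > 100 nM (the limit of > 100 nM in this assay, at which 1 of the 3 values shown sits). The change between them, (phenyl in place of 3,5-dichloro-4-hydroxyphenyl on a saturated chain carbon bound to a saturated ring carbon), therefore reads as an at least 2.3-fold higher number from compound 2 to compound 1 (0.37 log units; beyond the scatter), a step whose full size is not known.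

Compound 3 gives 17 nM in this assay, the lowest number among the measured compounds, and it lies beyond the scatter from compound 2. The difference between the core of compound 3 and the core of compound 2 is not broken down here.

Compound 4 `CC[C@H](C)[C@H]1C(=O)N[C@H](Cc2ccccc2)C(=O)N[C@@H](C(C)(C)O)C(=O)O[C@H](c2ccccc2)[C@H](C)/C=C/C=C(\C)[C@H](OC)C[C@@H]2O[C@@]2(C)C(=O)N1C` has not yet been measured in this assay. It differs from compound 3 by phenyl in place of 3,5-dichloro-4-hydroxyphenyl on a saturated chain carbon bound to a saturated ring carbon, the same change as from compound 2 to compound 1. On that parallel, the step from compound 3 to compound 4 is expected to be a 4.7-fold higher number from compound 3 to compound 4 (0.67 log units; beyond the scatter), resting on the measured step of an at least 2.3-fold higher number from compound 2 to compound 1 (0.37 log units; beyond the scatter) and on the value of compound 3, 17 nM. Compound 4 is therefore estimated at 80 nM, with a range from 35 nM to 300 nM.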

Compound 4, half-maximal inhibitory concentration: 20.9 nM
Compound 4: the middle estimate sits 3.8-fold (0.58 log units) above what was measured; measured number below the stated range.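

On the second core, in this assay, phenyl in place of 3,5-dichloro-4-hydroxyphenyl on a saturated chain carbon bound to a saturated ring carbon gives a 1.2-fold higher number from compound 3 to compound 4 (0.09 log units; within the scatter), so the two groups cannot be told apart on this core. This shows neither that the change acts differently on the two cores nor that it acts alike: the same change on two cores in this assay, an at least 2.3-fold higher number (0.37 log units; beyond the scatter) from compound 2 to compound 1 and a 1.2-fold higher number (0.09 log units; within the scatter) from compound 3 to compound 4; the limit leaves it open whether they differ. As far as these compounds go, compound 1 gives > 100 nM, a limit and not a number, so the full size of the step on the first core stays unknown, and one pair per core gives no rule for carrying the change across the series.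

The compounds shown carry the two chlorines and the hydroxyl together or not at all, so a dichlorophenyl or a hydroxyphenyl group on each core would be needed to read them apart. From the compounds shown here alone, the two cores also differ from each other in more than one place, and which of those differences matters remains open.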